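Chloro to Bromo Across Two Cores: Expected Cytotoxicity

The compounds below may be only part of what the source reports. "The series", "measured", "known", "first", "only" and "open" are said of these compounds alone.

Compound 1 `Cc1cc(CNS(=O)(=O)c2ccc(Cl)cc2)c(C)s1` and compound 2 `Cc1cc(CNS(=O)(=O)c2ccc(Br)cc2)c(C)s1` share one core and differ only by bromo in place of chloro on an aromatic carbon. In an ADME assay on MDCK cells (Canis lupus familiaris) for cytotoxicity, read by MTT assay, with a stated time of 24 h (a lower number here means that less compound is tolerated, a higher number that more compound is tolerated), compound 1 gives 52900 nM, and compound 2 gives 56400 nM, so that a 1.1-fold higher number from compound 1 to compound 2 (0.03 log units; within the scatter). Compound 3 `O=S(=O)(NCc1cc2ccccc2s1)c1ccc(Cl)cc1` is built on a second core; the difference between the two cores is not broken down here. In this assay compound 3 gives "not determined" (no result reported), so no result is available for it. Compound 4 `O=S(=O)(NCc1cc2ccccc2s1)c1ccc(Br)cc1` differs from compound 3 by bromo in place of chloro on an aromatic carbon, the same change as between compound 1 and compound 2. With nothing known for compound 3, the expectation for compound 4 rests on compound 1 and compound 2 alone, whose step a 1.1-fold higher number from compound 1 to compound 2 (0.03 log units; within the scatter) was small, so a similarly small step is expected here. Compound 4 is therefore expected to come out in this assay near 50000 nM, most likely between 15000 nM and 150000 nM.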

Compound 4, half-maximal cytotoxic concentration: > 174000 nM
Compound 4 gave a limit, no number; the forecaster's own chance of this, stated with the estimate: 25%; middle value at least 3.4-fold (0.54 log units) from the limit.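

In this assay compound 4 gives > 174000 nM, which is a limit and not a number. Within the data shown here, with no result for compound 3 either, no step between compound 3 and compound 4 can be read. As far as these compounds go, it stays open whether bromo in place of chloro matters as little on their core as on the core of compound 1.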